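The source may report more compounds than this note shows. Statements on the series, on what has been measured and on what is new or still open speak of the compounds shown alone.

Measured so far:
- compound 1 `COc1cccc(-c2n[nH]cc2N2CCNCC2)c1`: in an assay on isolated protein for binding affinity to 5-hydroxytryptamine receptor 1D (Homo sapiens) (on this read-out lower numbers stand for stronger inhibition and higher numbers for weaker inhibition), compound 1 gives > 10000 nM, which is a limit of the assay and not a number.
- compound 2 `COc1ccc(-c2n[nH]cc2N2CCNCC2)cc1`: in this assay compound 2 gives > 10000 nM, again a limit of the assay and not a number.

Among the compounds with values here, compound 2 stands at the limit of > 10000 nM in this assay, at which 2 of the 2 values shown sit; no number is known for it, only the limit, and the one further value shown is a limit as well. Compound 3 `c1ccc(-c2n[nH]cc2N2CCNCC2)cc1` differs from compound 2 by hydrogen in place of methoxy on an aromatic carbon. Within the data shown here, no step between measured compounds is available, so nothing measured sizes the change in this assay. With compound 2 itself at a limit, no move beyond the usual scatter is expected in either direction, though neither can be excluded. Compound 3 is expected to give about 15000 nM in this assay, within 3000 nM to 60000 nM, and most likely to be reported again only as a limit. The estimated step that the limit leaves unreadable from compound 2 to compound 3 is therefore expected to be essentially none.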

Compound 3, inhibition constant: > 10000 nM
Compound 3: only a limit was reported; the forecaster's own chance of this, stated with the estimate: 75%; the middle value is on the limit's open side.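

Compound 1, compound 2 and compound 3 are all reported only as a limit, not a number, so no step among them can be read: the limit of > 10000 nM in this assay, at which 3 of the 3 values shown sit.

The compounds shown leave open how strongly each binds in this assay, and whether hydrogen in place of methoxy changes that at all.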